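Piperazine N-demethylation and solubility in a thiazolone series

The compounds below may be only part of what the source reports. "The series", "measured", "known", "first", "only" and "open" are said of these compounds alone.

Measured compounds:
compound 1 `CN1CCN(c2ccc(/C=C3/SC(Nc4ccccc4)=NC3=O)cc2)CC1` gives 0.35 ug/mL in a physicochemical assay (Homo sapiens) for solubility, with a stated time of 18 h, at pH 7.4; on this read-out lower numbers stand for lower solubility and higher numbers for higher solubility
compound 2 `O=C1N=C(Nc2ccccc2)S/C1=C/c1ccc(N2CCNCC2)cc1` gives 1.68 ug/mL in this assay
compound 3 `CN1CCN(c2ccc(/C=C3/SC(Nc4ccccc4Cl)=NC3=O)cc2)CC1` gives 0.43 ug/mL in this assay

Within the data shown here, the one change whose effect is known within the set is hydrogen in place of methyl on an amine nitrogen in a ring. It produced a 4.8-fold higher number from compound 1 to compound 2 (0.68 log units; beyond the scatter). The cores of compound 1 and compound 3 differ by chloro in place of hydrogen on an aromatic carbon, which gave a 1.2-fold higher number from compound 1 to compound 3 (0.09 log units; within the scatter). Compound 3 therefore stands close to compound 1 in this assay, and the gap from compound 3 to compound 2 lies beyond the scatter.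

Compound 4 `O=C1N=C(Nc2ccccc2Cl)S/C1=C/c1ccc(N2CCNCC2)cc1` is not yet measured. It differs from compound 3 by hydrogen in place of methyl on an amine nitrogen in a ring. The place description is identical, word for word, to that of the change from compound 1 to compound 2, so this is the same change applied to a core that carries the chloro substituent. Among the measured compounds shown here, the step from compound 1 to compound 2 is the only precedent, and it rests on a single pair.

Compound 3 sits near compound 1 because of a 1.2-fold higher number from compound 1 to compound 3 (0.09 log units; within the scatter). For the measured compounds named here, the only precedent for the change is a 4.8-fold higher number from compound 1 to compound 2 (0.68 log units; beyond the scatter). The step from compound 3 to compound 4 in this assay is therefore expected to be of about that size, namely a 4.2-fold higher number from compound 3 to compound 4 (0.62 log units; beyond the scatter). Going by the values given here, compound 4 is therefore expected to give 1.8 ug/mL in this assay, with the range from 0.6 ug/mL to 5 ug/mL reflecting that only one prior pair supports the expectation.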

Compound 4, solubility: 0.14 ug/mL
Beside the measured number, compound 4's estimate is 13-fold (1.11 log units) above it, outside the stated range (below it).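

In this assay, hydrogen in place of methyl on an amine nitrogen in a ring does not carry over from one core to the other: with the chloro substituent present the change gives a 3.1-fold lower number from compound 3 to compound 4 (0.49 log units; beyond the scatter), whereas without it the change gave a 4.8-fold higher number from compound 1 to compound 2 (0.68 log units; beyond the scatter), so the two steps, each beyond the scatter, run in opposite directions. The chloro substituent depends on its partner in the same way, since a 1.2-fold higher number from compound 1 to compound 3 (0.09 log units; within the scatter) with 4-methylpiperazin-1-yl in place, while with piperazin-1-yl in place the same substitution gives a 12-fold lower number from compound 2 to compound 4 (1.08 log units; beyond the scatter), so the two changes do not add up across these four compounds. Each step rests on a single pair, so the reversal is shown only for these compounds and no general rule for the series follows from it, and nothing available bears on why the steps differ.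

As far as these compounds go, it remains open whether the reversal is specific to chloro or would recur with fluoro or methoxy on the same aromatic carbon. From the compounds shown here alone, it is also open whether an ethyl or acetyl group on the ring nitrogen would follow the methyl or the hydrogen on either core.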